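A few compounds are considered here, and "the series" means these few. Any claim that something is new, unique, unknown or untested is made for them only; others in the source may bear on it.

Compounds measured so far:
Compound 1 `N#Cc1ccc(-c2csc(N/N=C\c3ccco3)n2)cc1`: 40%
Compound 2 `O=[N+]([O-])c1ccc(-c2csc(N/N=C\c3ccco3)n2)cc1`: 40%

In an in vitro assay on BTI-TN-5B1-4 cells for inhibition of Amine oxidase [flavin-containing] A (Homo sapiens), read by Amplex Red, with a stated time of 15 min, tested at 100 uM (on this read-out higher numbers stand for more inhibition at the one concentration tested (going by the name of the read-out) and lower numbers for less inhibition), compound 1 gives 40% and compound 2 gives 40%. Within the data shown here, the one step taken so far, no change at the digits printed from compound 1 to compound 2 (within the scatter), swapped one group for another at the same place on the outer ring and left the read-out where it was. On the numbers shown, compound 2 therefore stands level with compound 1, with no difference that can be read beyond the scatter.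

The next compound, compound 3 `Fc1ccc(-c2csc(N/N=C\c3ccco3)n2)cc1`, again changes only that one place. The difference is fluoro in place of nitro on an aromatic carbon. Among the measured compounds shown here, the single measured step bears on this change in that it too replaced the group at the same position, and its size was no change at the digits printed from compound 1 to compound 2 (within the scatter). For the measured compounds named here, with only that step to go on, and it showing no movement, the expectation is that compound 3 will also stay close to compound 2, giving an expected step of a number 5 percentage points lower from compound 2 to compound 3 (within the scatter) in this assay. The estimate for compound 3 in this assay is 35%, with a range from 15% to 55%.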

Compound 3, a percentage reported as inhibition, at one concentration (the size of the read-out at that concentration, not a potency): 40%
Beside the measured number, compound 3's estimate is 5 percentage points below it; low and high end bracket the measured number.
By their numbers in this assay, from the lowest: compounds 1, 2 and 3 (each within the scatter of the next).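

In this assay, putting fluoro on this aromatic carbon, para to a large group, gives no change at the digits printed from compound 2 to compound 3 (within the scatter) when it replaces nitro and no change at the digits printed from compound 1 to compound 3 (within the scatter) when it replaces cyano. This extends the earlier finding to a third group and to a sharper difference in what is counted: nitro has 3 heavy atoms and 2 hydrogen-bond acceptors, while fluoro has 1 heavy atom and 0 hydrogen-bond acceptors. At this one test concentration, the read-out therefore does not separate these three groups, and the level seen is not tied to any one of them, although no measurement here explains why the three sit level.

Still open, as far as these compounds go, is whether a quite different group at the same place, such as an amine, a carboxylic acid or a longer alkyl chain, would also leave the read-out level, or whether one of them would move it beyond the usual scatter. Because each figure is the size of the inhibition at a single concentration and not a potency, these numbers also leave open whether the three compounds would stay level at other concentrations.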